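Amide Aryl Swap on a Shared Core: Toxicity Outlook

A few compounds are considered here, and "the series" means these few. Any claim that something is new, unique, unknown or untested is made for them only; others in the source may bear on it.

Compound 1, `COc1ccc(-c2cnc(NC(=O)c3ccccc3O)n2C)cc1` — a limit of the assay: > 100000 nM
Compound 2, `COc1ccc(-c2cnc(NC(C)=O)n2C)cc1` — a limit of the assay: > 100000 nM
Compound 3, `COc1ccc(-c2cnc(NC(=O)c3cccc(F)c3)n2C)cc1` — a limit of the assay: > 100000 nM

In a toxicity assay on THP-1 cells (Homo sapiens) for inhibition (on this read-out higher numbers stand for lower toxicity in this test and lower numbers for higher toxicity in this test), compound 1 gives > 100000 nM, which is a limit of the assay and not a number. Compound 2 likewise gives > 100000 nM, a limit. Compound 3 stands at > 100000 nM, again a limit rather than a measured number. All three results sit together at the limit of > 100000 nM in this assay, at which 3 of the 3 values shown sit, so none of the three compounds can be placed above or below another, and the steps between them, a step that the two limits leave unreadable from compound 1 to compound 2, a step that the two limits leave unreadable from compound 1 to compound 3 and a step that the two limits leave unreadable from compound 2 to compound 3, cannot be read in size or direction.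

Compound 4, `COc1ccc(-c2cnc(NC(=O)c3ccccc3Cl)n2C)cc1`, differs from compound 3 in one place: 2-chlorophenyl in place of 3-fluorophenyl on a carbonyl carbon. The steps that touch the same carbonyl carbon, from compound 1 to compound 3 and from compound 2 to compound 3, bear on this change. Both are unreadable, since every value sits at the limit of > 100000 nM in this assay, at which 3 of the 3 values shown sit. Three different groups on that carbonyl carbon, the 2-hydroxyphenyl, the methyl and the 3-fluorophenyl, all left the result at the limit, so no step beyond the scatter is expected in this assay for the 2-chlorophenyl either. Compound 4 is therefore expected to give about 100000 nM, within 40000 nM to 300000 nM, most likely reported again as a limit. The estimated step is a number no higher from compound 3 to compound 4 (the limit leaves the size open).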

Compound 4, half-maximal cytotoxic concentration: > 50000 nM
Compound 4 was reported as a limit; the forecaster's own chance of this, stated with the estimate: 80%; the middle value lies beyond the limit too.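

In this assay compound 4 gives > 50000 nM, which is a limit of the assay and not a number. None of the steps linking compound 4 to compound 1, compound 2 or compound 3 can be read, in size or in direction. The compounds shown leave open whether any group on that carbonyl carbon changes the toxicity seen in this test.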